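The source may report more compounds than this note shows. Statements on the series, on what has been measured and on what is new or still open speak of the compounds shown alone.

Measured compounds in the series:
compound 1 `CN(C)c1ccc(C(=O)Nc2cccc(NC(=O)COc3ccc4c(c3)CCC(=O)N4)c2)cc1`, compound 2 `COc1cc(OCC(=O)Nc2cccc(NC(=O)c3ccc(N(C)C)cc3)c2)ccc1C=O`, compound 3 `COc1ccc(OCC(=O)Nc2cccc(NC(=O)c3ccc(N(C)C)cc3)c2)cc1OC`.

In an assay on isolated protein for inhibition of Rho-associated protein kinase 1 (Homo sapiens), read by scintillation counting, radiometric assay and 33P incorporation, with a stated time of 40 min, in the presence of a further agent that is not named here (on this read-out higher numbers stand for weaker inhibition and lower numbers for stronger inhibition), compound 2 gives 3740 nM. For compound 1 the assay reports only a limit, > 10000 nM. For compound 3 it likewise reports only a limit, > 10000 nM. Compound 2 therefore stands as the only number shown; the other two values are limits (the limit of > 10000 nM in this assay, at which 2 of the 3 values shown sit).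

Compound 4 `COc1ccc(OCC(=O)Nc2cccc(NC(=O)c3ccc(N(C)C)cc3)c2)cc1F` differs from compound 2 by a group of 9 heavy atoms (7 carbon, 1 oxygen, 1 fluorine; one six-membered aromatic ring of carbon only) in place of a group of 10 heavy atoms (8 carbon, 2 oxygen; one six-membered aromatic ring of carbon only), on an oxygen on a saturated carbon. The formyl of compound 2 is lost here, as it is from compound 2 to compound 3, where the change gave an at least 2.6-fold higher number from compound 2 to compound 3 (0.42 log units; beyond the scatter). Within the data shown here, the step from compound 1 to compound 2 was an at least 2.6-fold lower number from compound 1 to compound 2 (0.42 log units; beyond the scatter), the formyl-bearing side chain being the one with the number. With the formyl gone and fluorine on the 3-fluoro-4-methoxyphenyl instead, compound 4 is expected to move toward the weaker end, by about a 3.2-fold higher number from compound 2 to compound 4 (0.51 log units; beyond the scatter). The estimate for compound 4 is 12000 nM, expected to lie between 4000 nM and 40000 nM, with a fair chance that only a limit is returned.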

Compound 4, half-maximal inhibitory concentration: 1820 nM
Compound 4: middle estimate off by 6.6-fold (0.82 log units), on the high side; the whole stated range lies above it.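

The formyl is not required for a measurable number in this series: the 3-fluoro-4-methoxyphenyl of compound 4 carries none, and replacing the group of compound 2 gives a 2.1-fold lower number from compound 2 to compound 4 (0.31 log units; beyond the scatter). Losing the formyl therefore does not by itself send a compound to the limit, as the contrast with compound 3 shows, where fluoro in place of methoxy on an aromatic carbon gives an at least 5.4-fold lower number from compound 3 to compound 4 (0.73 log units; beyond the scatter). The group of compound 4 also compares well with the side chain of compound 1, giving an at least 5.4-fold lower number from compound 1 to compound 4 (0.73 log units; beyond the scatter).

The steps from compound 1 and compound 3 each rest on a limit, so only their minimum size can be read: the limit of > 10000 nM in this assay, at which 2 of the 4 values shown sit. Still open, going by these compounds, is whether chloro, hydroxy or an amine in place of the fluoro holds the number, and whether the fluoro does so without the methoxy.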